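Changing the Amide Group of Compound 3

The source may report more compounds than this note shows. Statements on the series, on what has been measured and on what is new or still open speak of the compounds shown alone.

In an ADME assay on microsomes from liver (Mus musculus, strain CD-1) for metabolic stability, read by LC-MS, tested at 2 uM (a lower number here means that the compound disappears faster, a higher number that the compound lasts longer), compound 3 `CN(C)C(=O)c1ccncc1Nc1cc(-c2ccc3ccn(C)c3c2)c2nccnc2c1` gives 0.35 h. That value lies within the scatter of both other measured compounds: compound 1 `Cn1ccc2ccc(-c3cc(Nc4ccccc4S(=O)(=O)Nc4cncnc4)cc4nccnc34)cc21` at 0.683 h and compound 2 `CN(Cc1cncnc1)S(=O)(=O)c1ccccc1Nc1cc(-c2ccc3ccn(C)c3c2)c2nccnc2c1` at 0.2 h. Compound 4 `Cn1cc(CNC(=O)c2ccncc2Nc2cc(-c3ccc4ccn(C)c4c3)c3nccnc3c2)cn1` carries ((1-methyl-1H-pyrazol-4-yl)methyl)amino in place of dimethylamino on a carbonyl carbon. Going by the values given here, the only measured step is modest, a 3.4-fold lower number from compound 1 to compound 2 (0.53 log units; beyond the scatter), and it placed methyl((pyrimidin-5-yl)methyl)amino where (pyrimidin-5-yl)amino had been on a sulfonyl sulfur. With a different attachment atom, it is only a loose guide. A slightly lower number is expected, a 1.4-fold lower number from compound 3 to compound 4 (0.15 log units; within the scatter), which would stay within the scatter. For compound 4, the estimated half-life is 0.25 h, with an expected range from 0.1 h to 0.6 h.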

Compound 4, half-life: 0.267 h
Compound 4: middle estimate off by 1.1-fold (0.03 log units), on the low side, and the stated range covers the measured number.
By their numbers in this assay, from the lowest: compounds 2, 4, 3 and 1 (each within the scatter of the next, the first and the last beyond it).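

In this assay, the step is a 1.3-fold lower number from compound 3 to compound 4 (0.12 log units; within the scatter), so on this carbonyl carbon, dimethylamino and the larger ((1-methyl-1H-pyrazol-4-yl)methyl)amino, which adds a five-membered aromatic ring and a hydrogen-bond donor, cannot be told apart. This position therefore takes that exchange without a change in half-life beyond the scatter. No measurement at hand explains this result. Going by these compounds, it remains open whether a morpholine amide or a plain unsubstituted amide on the same carbonyl carbon would stay as close to compound 3.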